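Phenyl Analogue Compound 4 Expected to Remain Inactive

A few compounds are considered here, and "the series" means these few. Any claim that something is new, unique, unknown or untested is made for them only; others in the source may bear on it.

Compound 1, `CC(O)(CS(=O)(=O)c1ccc(Br)cc1)c1nc(-c2ccccc2)no1`, gives > 100000 nM, a limit of the assay.
Compound 2, `CC(O)(CS(=O)(=O)c1ccccc1)c1nc(-c2ccccc2)no1`, gives > 100000 nM, also a limit.
Compound 3, `CC(O)(CS(=O)(=O)c1ccc(F)cc1)c1nc(-c2ccc(F)c(Cl)c2)no1`, gives > 100000 nM, again a limit.

All three were measured in a functional assay on DU-145 cells (Homo sapiens) for cytotoxicity, read by MTT assay; a lower number here means a stronger inhibitor, a higher number a weaker inhibitor. Compound 3 thus stands at the limit of > 100000 nM in this assay, at which 3 of the 3 values shown sit, with no number of its own. Compound 4, `CC(O)(CS(=O)(=O)c1ccc(F)cc1)c1nc(-c2ccccc2)no1`, differs from compound 3 by phenyl in place of 3-chloro-4-fluorophenyl on an aromatic carbon. For the measured compounds named here, no measured step touches this group. Going by the values given here, the only measured step, a step that the two limits leave unreadable from compound 1 to compound 2, alters the ring attached to the sulfonyl group instead, and its size cannot be read because a step that the two limits leave unreadable from compound 1 to compound 2 runs between two limits. Compounds 1 and 2 already carry the entering phenyl group and both sit at the limit. Compound 4 is therefore expected to give 150000 nM, within 50000 nM to 1000000 nM, most likely again as a limit. The step that the limit leaves unreadable from compound 3 to compound 4 is expected to show no change beyond the scatter.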

Compound 4, half-maximal inhibitory concentration: > 100000 nM
Compound 4 gave a limit, no number (the forecaster's own chance of this, stated with the estimate: 85%); the middle value is on the limit's open side.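

No step can be read among compound 1, compound 2, compound 3 and compound 4, since each gives only a limit: the limit of > 100000 nM in this assay, at which 4 of the 4 values shown sit.

The compounds shown leave open whether any change to the shared core would give a measurable value in this assay.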